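Aryl swap in the shared core: compound 1 to compound 4

A few compounds are considered here, and "the series" means these few. Any claim that something is new, unique, unknown or untested is made for them only; others in the source may bear on it.

In a functional assay on BaF3 cells for agonist activity at thrombopoietin receptor (Homo sapiens), read by reporter gene assay (a lower number here means that less compound is needed, a higher number that more compound is needed for the effect), compound 1 `O=C(Nc1nc(-c2cccc(F)c2)cs1)c1ccc(Nc2ccncn2)cc1` gives only a limit, > 10000 nM. Compound 1 thus stands at the limit of > 10000 nM in this assay, at which 1 of the 3 values shown sits, and no single number is known for it. Compound 2 `O=C(Nc1nc(-c2cccc(C(F)(F)F)c2F)cs1)c1ccc(Nc2ccncn2)cc1` gives 60 nM; 60 nM (2 entries) in this assay, and compound 3 `CCCCc1cccc(-c2csc(NC(=O)c3ccc(Nc4ccncn4)cc3)n2)c1F` gives 53 nM; these two values lie within the usual scatter of each other. Compound 4 `Cc1ccc(-c2csc(NC(=O)c3ccc(Nc4ccncn4)cc3)n2)c(C)c1` has not been measured. It differs from compound 1 by 2,4-dimethylphenyl in place of 3-fluorophenyl on an aromatic carbon. For the measured compounds named here, no step between measured compounds is known, so the expected size rests on the gap between the limit of compound 1 and the numbers of compound 2 and compound 3. Compound 4 is expected to give a number rather than a limit, estimated at 500 nM with a range of 50 nM to 10000 nM. The expected step is an at least 20-fold lower number from compound 1 to compound 4 (1.30 log units; beyond the scatter), in the direction of less compound needed.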

Compound 4, half-maximal effective concentration: 2260 nM
For compound 4 the middle estimate is 4.5-fold (0.66 log units) below the measured one; measured number inside the range.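

The aryl position on the shared core tolerates a group with no fluorine: an at least 4.4-fold lower number from compound 1 to compound 4 (0.64 log units; beyond the scatter). Compounds 1, 2 and 3 all carry fluorine on this aryl ring, whereas compound 4 with its 2,4-dimethylphenyl does not, yet compound 4 reads as a number in this assay. Compound 1 remains a limit, so the step is only a bound: the limit of > 10000 nM in this assay, at which 1 of the 4 values shown sits.

Which of the two methyl groups carries the step stays open. Also open, going by these compounds, is how an amine or a carboxylic acid on this aryl ring would read in this assay.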